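Swapping pyridin-3-yl for 4-chlorophenyl at the assay limit

The source may report more compounds than this note shows. Statements on the series, on what has been measured and on what is new or still open speak of the compounds shown alone.

In a functional assay on LNCaP cells (Homo sapiens) for antiproliferative activity, read by MTT assay, with a stated time of 24 h (a higher number here means a weaker inhibitor, a lower number a stronger inhibitor), compound 1 (`COc1ccc(-c2noc(-c3ccccc3)n2)cc1OC1CCCC1`) gives > 1000000 nM, which is a limit of the assay and not a number. Compound 2 (`COc1ccc(-c2noc(-c3cccnc3)n2)cc1OC1CCCC1`) gives > 1000000 nM, which is also only a limit. The whole picture so far is the limit of > 1000000 nM in this assay, at which 2 of the 2 values shown sit.

Compound 3 (`COc1ccc(-c2noc(-c3ccc(Cl)cc3)n2)cc1OC1CCCC1`) carries 4-chlorophenyl in place of pyridin-3-yl on an aromatic carbon. Going by the values given here, the one measured step that bears on this change is a step that the two limits leave unreadable from compound 1 to compound 2, and it offers no size or direction to carry over. No step beyond the usual scatter is therefore expected in this assay. The expected change is a number no higher from compound 2 to compound 3 (the limit leaves the size open). Compound 3 is estimated at 1000000 nM, with an expected range from 300000 nM to 3000000 nM, and the assay may well report only a limit again.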

Compound 3, half-maximal inhibitory concentration: 20800 nM
Compound 3: the middle estimate sits 48-fold (1.68 log units) above what was measured; the measured number lies below the stated range.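

The aromatic carbon of the five-membered aromatic ring with 2 nitrogen and 1 oxygen proves sensitive to what it carries: in this assay, 4-chlorophenyl in place of pyridin-3-yl gives an at least 48-fold lower number from compound 2 to compound 3 (1.68 log units; beyond the scatter). The closest comparison is with the plain phenyl group, where a single chloro in place of hydrogen gives an at least 48-fold lower number from compound 1 to compound 3 (1.68 log units; beyond the scatter), so one added atom is enough to move a compound from the limit to a readable number. Both steps start from a limit of the assay and not from a number, and compound 3 alone has left that limit: the limit of > 1000000 nM in this assay, at which 2 of the 3 values shown sit.

Going by these compounds, whether another group in place of the chloro, such as a methoxy, an amine or a carboxylic acid, would also give a readable number remains open. The compounds shown also cannot tell why the chloro has this effect, or whether it would persist elsewhere on the phenyl ring.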